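A few compounds are considered here, and "the series" means these few. Any claim that something is new, unique, unknown or untested is made for them only; others in the source may bear on it.

Compound 3 `C=CC(=O)Nc1cccc(Nc2ncnc(Nc3ccc(-c4ccc(Cl)nc4)cc3)n2)c1` carries a 6-chloropyridin-3-yl group on the shared core, yet in a functional assay on Raji cells (Homo sapiens) for antiproliferative activity, read by CCK-8 assay, with a stated time of 24 h (on this read-out lower numbers stand for stronger inhibition and higher numbers for weaker inhibition), compound 3 is recorded as "not determined" (no result reported), so it has no single number. Its nearest measured relatives are compound 1 `C=CC(=O)Nc1cccc(Nc2ncnc(Nc3ccc(C(=O)Nc4ccccn4)cc3)n2)c1`, which in this assay gives 15600 nM, and compound 2 `C=CC(=O)Nc1cccc(Nc2ncnc(Nc3ccc(-c4ccc(C)nc4)cc3)n2)c1`, which in this assay gives 13800 nM. Compound 4 `C=CC(=O)Nc1cccc(Nc2ncnc(Nc3ccc(C(=O)N4CCCCC4)cc3)n2)c1` differs from compound 3 by (piperidin-1-yl)carbonyl in place of 6-chloropyridin-3-yl on an aromatic carbon, so that a carbonyl-linked group again stands on an aromatic carbon where compound 3 bears an aromatic ring. Because a 1.1-fold lower number from compound 1 to compound 2 (0.05 log units; within the scatter) lay within the scatter for an exchange of this same kind, no step beyond the scatter is expected for compound 4 in this assay in either direction. Compound 4 is therefore estimated at 15000 nM, with a range from 5000 nM to 45000 nM.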

Compound 4, half-maximal inhibitory concentration: 5140 nM
For compound 4 the middle estimate is 2.9-fold (0.47 log units) above the measured one, within the range that was stated.
By their numbers in this assay, from the lowest: compound 4; then compounds 2 and 1 (each within the scatter of the next).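

On this aromatic carbon, this assay now shows changes beyond the scatter: (piperidin-1-yl)carbonyl in place of 6-methylpyridin-3-yl gives a 2.7-fold lower number from compound 2 to compound 4 (0.43 log units; beyond the scatter), and piperidin-1-yl in place of (pyridin-2-yl)amino on the carbonyl carbon gives a 3.0-fold lower number from compound 1 to compound 4 (0.48 log units; beyond the scatter). Both steps are modest, but unlike the earlier exchange they show that the number responds to the group at this position. Nothing available explains these steps. As far as these compounds go, it remains open whether the lower number depends on the piperidine ring itself, or would persist with a morpholine ring or an open-chain diethylamino group on the same carbonyl.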